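Bromo to methoxy on the shared core

The compounds below may be only part of what the source reports. "The series", "measured", "known", "first", "only" and "open" are said of these compounds alone.

Two compounds carry a read-out so far. Compound 1 `CCOc1ccc(-c2nn(-c3ccccc3)cc2C2=NOC3C(=O)N(C)C(=O)C23)cc1` gives 47.5% in a functional assay on the whole organism (Abdomen, strain Swiss albino) with Mus musculus as the target, with stated times of 10 min and 5 min, at a dose of 30 mg/kg by the oral route; a lower number here means a weaker effect, a higher number a stronger effect of the compound at the dose given. Compound 2 `Brc1ccc(-c2nn(-c3ccccc3)cc2-c2cc(-c3ccccc3)on2)cc1` gives 31.4% in this assay, the lower of the two numbers, with compound 1 lying above it by a margin beyond the usual scatter. The two measured compounds do not differ in one place only, so their values show nothing about the group on the six-membered ring by itself.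

Compound 3 `COc1ccc(-c2nn(-c3ccccc3)cc2-c2cc(-c3ccccc3)on2)cc1` is unmeasured. It differs from compound 2 by methoxy in place of bromo on an aromatic carbon. Going by the values given here, no measured step bears on this change, and compound 1 is not a one-place neighbour of either compound. The step from compound 2 to compound 3 is expected to be a number 4.6 percentage points higher from compound 2 to compound 3 (within the scatter) in this assay, small and not clearly beyond the scatter in either direction. Compound 3 is estimated at 36%, ranging from 20% to 55%.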

Compound 3, a percentage reported as activity, at one dose (the size of the read-out at that dose, not a potency): 31%
Estimate against measurement, compound 3: 5 percentage points above, and the stated range covers the measured number.
By their numbers in this assay, from the lowest: compounds 3 and 2 (each within the scatter of the next); then compound 1.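

Going by these compounds alone, the change from 4-bromophenyl to 4-methoxyphenyl gives a number 0.4 percentage points lower from compound 2 to compound 3 (within the scatter) in this assay, the only step so far that can be read at this position. At the dose given, bromo and methoxy on this aromatic carbon are therefore not told apart by this read-out, something the earlier pair of compounds could not show. No measurement on hand bears on why the two groups read alike.

As far as these compounds go, whether an amine or a carboxylic acid in place of bromo would move the read-out beyond the scatter remains open. Also open, from the compounds shown here alone, is which structural difference goes with the higher number of compound 1, since that compound differs from compound 2 and compound 3 in more than one place.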